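The compounds below may be only part of what the source reports. "The series", "measured", "known", "first", "only" and "open" are said of these compounds alone.

Measured in a functional assay on A549 cells (Homo sapiens) for antiproliferative activity, read by MTT assay, with a stated time of 48 h; a higher number here means a weaker inhibitor, a lower number a stronger inhibitor:
- compound 1 `Cn1cc(C2=C(c3nn(CCCN4CCCCC4)c4ncccc34)C(=O)N(c3ccccc3)C2=O)c2ccccc21`: 20600 nM
- compound 2 `Cn1cc(C2=C(c3nn(CCn4ccnc4)c4ncccc34)C(=O)N(c3ccccc3)C2=O)c2ccccc21`: 43100 nM

Compound 2 has the higher of the two numbers, which makes it the weaker inhibitor, and compound 1 is its nearest neighbour. Compound 3 `Cn1cc(C2=C(c3nn(CCCn4ccnc4)c4ncccc34)C(=O)N(c3ccccc3)C2=O)c2ccccc21` differs from compound 2 in one place: (1H-imidazol-1-yl)methyl in place of 1H-imidazol-1-yl on a saturated chain carbon, two bonds along the chain from an aromatic nitrogen. Here (1H-imidazol-1-yl)methyl stands in place of 1H-imidazol-1-yl on a saturated chain carbon, two bonds along the chain from an aromatic nitrogen. Among the compounds with values here, only one measured step bears on this: a 2.1-fold higher number from compound 1 to compound 2 (0.32 log units; beyond the scatter). That modest step changed the ring and the chain together, so it can only partly guide this chain-only change. A small move toward a lower number is therefore expected in this assay, though it may stay within the scatter. The estimated step is a 1.3-fold lower number from compound 2 to compound 3 (0.13 log units; within the scatter). For compound 3 the expected value is 32000 nM, within an estimated range of 15000 nM to 65000 nM.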

Compound 3, half-maximal inhibitory concentration: 1560 nM
For compound 3 the middle estimate is 21-fold (1.31 log units) above the measured one; measured number below the stated range.
By their numbers in this assay, from the lowest: compound 3; then compound 1; then compound 2.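

In this assay, within the data shown here, the longer chain alone gives a 28-fold lower number from compound 2 to compound 3 (1.44 log units; beyond the scatter), so this chain length matters far more than the earlier compounds suggested. With the 3-carbon propyl chain kept, 1H-imidazol-1-yl in place of piperidin-1-yl gives a 13-fold lower number from compound 1 to compound 3 (1.12 log units; beyond the scatter), which shows that the group carried by the chain matters as well, and that the modest 2.1-fold higher number from compound 1 to compound 2 (0.32 log units; beyond the scatter) combined two changes pulling in opposite directions. Nothing measured here explains why either change has so large an effect.

The compounds shown leave open whether a longer chain, such as 4-(1H-imidazol-1-yl)butyl, would lower the number further or raise it again. They also leave open whether the effect is particular to 1H-imidazol-1-yl or would hold with another ring in its place, such as morpholine or pyrazole.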